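Hydroxyurea series: sulfonamidophenyl replacing dichlorophenyl

The source may hold more compounds than are shown below. What is called first, only, known or untested is meant among the compounds shown, and "the series" means these compounds.

Of the compounds shown here, three of the shared core have been measured in an assay for inhibition of Polyunsaturated fatty acid 5-lipoxygenase (Homo sapiens), read by HPLC, with stated times of 15 min and 10 min; a lower number here means a stronger inhibitor, a higher number a weaker inhibitor. Compound 1 `CC(C#Cc1ccc(C(=O)NCc2ccccc2C(F)(F)F)o1)N(O)C(N)=O` gives 4000 nM. Compound 3 `CC(C#Cc1ccc(C(=O)NCc2ccccc2C(F)(F)F)cc1)N(O)C(N)=O` gives 1000 nM. Compound 2 `C[C@H](C#Cc1cccc(C(=O)NCCC(c2ccccc2)c2ccc(Cl)c(Cl)c2)c1)N(O)C(N)=O` gives 96 nM, the lowest number of the three, and its steps to compound 3 and to compound 1 both lie beyond the scatter, so on these numbers compound 2 is the strongest inhibitor of the set.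

Compound 4 `C[C@H](C#Cc1cccc(C(=O)NCCC(c2ccccc2)c2ccc(NS(C)(=O)=O)cc2)c1)N(O)C(N)=O` is the unmeasured analogue of compound 2. The change is 4-(methanesulfonamido)phenyl in place of 3,4-dichlorophenyl on a saturated chain carbon bound to an aromatic carbon and a saturated chain carbon. Within the data shown here, no pair of measured compounds differs by this change alone, so the size of such a step is not known from the series, and the expectation rests only on the value of compound 2. A moderate step toward a weaker inhibitor, beyond the scatter, is expected, with wide uncertainty in both directions. Compound 4 is therefore estimated to give 350 nM, with a range from 80 nM to 1500 nM. The step of a 3.6-fold higher number from compound 2 to compound 4 (0.56 log units; beyond the scatter) is expected to exceed the scatter while leaving the resulting number within the span of the measured compounds.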

Compound 4, half-maximal inhibitory concentration: 900 nM
Beside the measured number, compound 4's estimate is 2.6-fold (0.41 log units) below it; the measured number falls inside the stated range.
By their numbers in this assay, from the lowest: compound 2; then compounds 4 and 3 (each within the scatter of the next); then compound 1.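

In this assay, among these compounds, this place, a saturated chain carbon bound to an aromatic carbon and a saturated chain carbon, now has its first measured step, a 9.4-fold higher number from compound 2 to compound 4 (0.97 log units; beyond the scatter); the earlier compounds offered no pair differing in one place. The exchange of 3,4-dichlorophenyl for 4-(methanesulfonamido)phenyl therefore moves the series toward a weaker inhibitor by more than the scatter, showing that the number responds to what this aromatic group carries, even with the rest of the molecule held constant. The entering group brings a hydrogen-bond donor and acceptors that the leaving group lacks, but nothing measured links these or any other feature to the size of the step.

Among the compounds shown here, the single step removes both chlorines and adds the methanesulfonamido group at once, so it cannot show how much each part contributes; an unsubstituted phenyl, a chlorophenyl or a phenyl bearing an amine or a carboxylic acid at this place would help separate them. From the compounds shown here alone, whether a step of this size would recur on another core also stays open, as this exchange is read on one pair only.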